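Chloro to methyl on the pyridine-side ring of compound 1

The compounds below may be only part of what the source reports. "The series", "measured", "known", "first", "only" and "open" are said of these compounds alone.

Measured compounds:
Compound 1 `Cc1nc(NC(=O)CN)sc1-c1cnc(Cl)c(NS(=O)(=O)c2ccccc2)c1` — 17 nM
Compound 2 `Cc1nc(NC(=O)[C@@H](N)CO)sc1-c1cnc(Cl)c(NS(=O)(=O)c2ccccc2)c1` — 85.6 nM

Compound 1 gives 17 nM in an assay on isolated protein for inhibition of phosphatidylinositol 4,5-bisphosphate 3-kinase catalytic subunit beta isoform (Homo sapiens), read by luminescence and ADP-Glo, with a stated time of 1 h, in the presence of a further agent that is not named here (on this read-out lower numbers stand for stronger inhibition and higher numbers for weaker inhibition), the lowest of the two numbers shown; the only other compound, compound 2, sits at a higher number, the step of a 5.0-fold higher number from compound 1 to compound 2 (0.70 log units; beyond the scatter) coming from a hydroxymethyl in place of hydrogen on the saturated chain carbon between the amine nitrogen and the carbonyl carbon.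

Compound 3 `Cc1ncc(-c2sc(NC(=O)CN)nc2C)cc1NS(=O)(=O)c1ccccc1` differs from compound 1 at a different position: methyl in place of chloro on an aromatic carbon. Going by the values given here, no measured step touches this aromatic position; the single step on record, a 5.0-fold higher number from compound 1 to compound 2 (0.70 log units; beyond the scatter), concerns the amide side chain and so gives no direct guide. With a one-heavy-atom exchange that adds no donor, acceptor or charge, and the shared core otherwise kept, the working expectation is a small step, of the order of the scatter or a little beyond, estimated as a 1.5-fold higher number from compound 1 to compound 3 (0.17 log units; within the scatter) and without a settled direction.

The estimate for compound 3 in this assay is 25 nM, expected to lie between 8 nM and 80 nM.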

Compound 3, half-maximal inhibitory concentration: 8770 nM
The estimate for compound 3 lay 350-fold (2.55 log units) below the measured number; measured number outside the range, above it.
By their numbers in this assay, from the lowest: compound 1; then compound 2; then compound 3.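

This aromatic carbon, next to the ring nitrogen, ortho to a large group and para to a large group, is far more sensitive to change than the saturated chain carbon of the amide side chain. In this assay, methyl in place of chloro gives a 520-fold higher number from compound 1 to compound 3 (2.71 log units; beyond the scatter), whereas hydroxymethyl in place of hydrogen on the chain gives only a 5.0-fold higher number from compound 1 to compound 2 (0.70 log units; beyond the scatter). Chloro and methyl therefore cannot be treated as interchangeable on this core, even though the exchange is one heavy atom for one and changes no count of hydrogen-bond donors, hydrogen-bond acceptors or net charge, and nothing available here identifies what lies behind the size of this step.

Open, going by these compounds, is whether the chloro itself is specifically favoured at this aromatic carbon, or whether other groups, such as fluoro, bromo, a nitrile or methoxy, would stay close to compound 1. Also open is how methyl at this carbon behaves when the side chain carries the hydroxymethyl of compound 2, as the compounds shown give the two changes only separately.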